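The source may report more compounds than this note shows. Statements on the series, on what has been measured and on what is new or still open speak of the compounds shown alone.

Of the compounds shown here, three of related build have been tested for how strongly they hold back the growth of a prostate cancer cell line. Compound 1 `O=C(/C(=C\c1ccc(Cl)cc1)SCc1ccc(Cl)cc1)c1ccc(Br)cc1`, compound 2 `O=C(/C(=C\c1ccc(O)cc1)SCc1ccc(F)cc1)c1ccc(Br)cc1` and compound 3 `O=C(/C(=C/c1ccc(Cl)cc1)Cc1c[nH]c2ccccc12)c1ccc(Cl)cc1Cl` share a core in which a carbonyl sits next to a double-bonded chain carbon. In a functional assay on DU-145 cells (Homo sapiens) for inhibition, read by trypan blue exclusion, with a stated time of 96 h (on this read-out higher numbers stand for weaker inhibition of growth and lower numbers for stronger inhibition of growth), compound 1 gives 10000 nM, compound 2 gives 10000 nM and compound 3 gives 10000 nM, so compound 3 stands level with both, within the scatter. Compound 4 `O=C(/C(=C/c1ccc(Cl)cc1)Cc1ccc(Cl)cc1)c1ccc(Cl)cc1Cl` differs from compound 3 in one place: 4-chlorophenyl in place of 1H-indol-3-yl on a saturated chain carbon bound to a double-bonded chain carbon. Going by the values given here, no measured step tells what such a change does here, so the step is expected to stay within the scatter, with no change at the digits printed from compound 3 to compound 4 (within the scatter). For compound 4 the estimate in this assay is 10000 nM, between 4000 nM and 25000 nM.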

Compound 4, concentration for 50% growth inhibition: 10000 nM
Compound 4: the middle estimate sits on the measured number at the digits printed; measured number inside the range.
By their numbers in this assay, from the lowest: compounds 1, 2, 3 and 4 (each within the scatter of the next).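

Putting 4-chlorophenyl in place of 1H-indol-3-yl on a saturated chain carbon bound to a double-bonded chain carbon gives no change at the digits printed from compound 3 to compound 4 (within the scatter) in this assay for this pair. At this place, then, the hydrogen-bond donor and the five-membered aromatic ring of 1H-indol-3-yl can go without the number moving. Nothing measured here offers a reason for this.

From the compounds shown here alone, since all four compounds print the same number, it stays open whether any group at this place could bring it lower. An amine, a carboxylic acid or a longer chain there would be a further test.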